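Moving the methyl on the aryl ring of the amide nitrogen

This account rests on a few compounds, and the source may have more. Where it says the series, first, only, none or still open, it means among the compounds named here.

Compound 1 `O=C1CC(c2nc(-c3cccc(Cl)c3)no2)CN1c1ccc(Cl)cc1` gives 140 nM in an in vitro functional assay on HEK293-A cells for positive allosteric modulation of metabotropic glutamate receptor 5 (Homo sapiens), read by FLIPR and calcium flux (on this read-out higher numbers stand for an effect only at larger amounts of compound and lower numbers for an effect already at smaller amounts), and compound 2 `O=C1CC(c2nc(-c3cccc(Cl)c3)no2)CN1c1ccc(Cl)c(Cl)c1` gives 460 nM in this assay, the two being linked by a 3.3-fold higher number from compound 1 to compound 2 (0.52 log units; beyond the scatter). Compound 3 `Cc1cccc(N2CC(c3nc(-c4cccc(Cl)c4)no3)CC2=O)c1` stands apart: in this assay compound 3 reaches only > 10000 nM, which is a limit of the measurement and not a number (the limit of > 10000 nM in this assay, at which 1 of the 3 values shown sits). The steps leading to it are an at least 71-fold higher number from compound 1 to compound 3 (1.85 log units; beyond the scatter) and an at least 21-fold higher number from compound 2 to compound 3 (1.33 log units; beyond the scatter), both large and both beyond the scatter.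

Compound 4 `Cc1ccc(N2CC(c3nc(-c4cccc(Cl)c4)no3)CC2=O)cc1` differs from compound 3 by 4-methylphenyl in place of 3-methylphenyl on an amide-type nitrogen in a ring. The measured steps that bear on this change are the two just named: compounds 1 and 2 carry 4-chlorophenyl and 3,4-dichlorophenyl on the amide-type nitrogen and give numbers, whereas compound 3 with 3-methylphenyl gives only a limit. Among the compounds with values here, no measured step compares 4-methylphenyl directly with 3-methylphenyl, so the direction rests on the resemblance of compound 4 to compounds 1 and 2 in where the ring is substituted.

On that basis compound 4 is expected to fall back below the limit, with a step of an at least 6.6-fold lower number from compound 3 to compound 4 (0.82 log units; beyond the scatter) in this assay. The estimate for compound 4 is 1500 nM, in a range from 300 nM to 10000 nM.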

Compound 4, half-maximal effective concentration: 630 nM
The estimate for compound 4 lay 2.4-fold (0.38 log units) above the measured number; the measured number falls inside the stated range.
By their numbers in this assay, from the lowest: compound 1; then compounds 2 and 4 (each within the scatter of the next). At a limit, above all of these: compound 3.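

Within the data shown here, the result gives the first direct comparison of the two methylphenyl groups on the amide-type nitrogen, which have the same atoms joined differently: an at least 15-fold lower number from compound 3 to compound 4 (1.20 log units; beyond the scatter) in this assay, so where the methyl sits on the aryl ring decides whether compound 3 or compound 4 gives a measurable number. From the compounds shown here alone, the value for compound 3 remains a limit of the measurement and not a number, so the true size of this step stays unknown: the limit of > 10000 nM in this assay, at which 1 of the 4 values shown sits. It also shows that a chloro is not needed for a measurable number, although 4-methylphenyl does not fully match 4-chlorophenyl, with a 4.5-fold higher number from compound 1 to compound 4 (0.65 log units; beyond the scatter), while it stands level with 3,4-dichlorophenyl, with a 1.4-fold higher number from compound 2 to compound 4 (0.14 log units; within the scatter).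

The compounds shown leave open whether a lone 3-chlorophenyl group on the amide-type nitrogen would also end at a limit like 3-methylphenyl, or would give a number as 3,4-dichlorophenyl does. They also leave open how a 4-methoxyphenyl or 4-trifluoromethylphenyl group would compare with 4-methylphenyl and 4-chlorophenyl, and they give no reason for the gap between the two methylphenyl groups.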